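Methyl-oxazole for thiazole: expected clearance of compound 4

The compounds below may be only part of what the source reports. "The series", "measured", "known", "first", "only" and "open" are said of these compounds alone.

Of the compounds shown here, three of the shared core have been measured in an ADME assay on microsomes from liver (Homo sapiens) for metabolic stability; a higher number here means faster removal of the compound, a lower number slower removal. Compound 1 `Cc1cc2c(cc1Cc1ccc(-c3cocn3)cc1)C(=O)N([C@H]1CCOC[C@@H]1O)C2` gives only a limit of the assay, < 8 mL/min/kg, in this assay. Compound 2 `Cc1cc2c(cc1Cc1ccc(-n3cccn3)cc1)C(=O)N([C@H]1CCOC[C@@H]1O)C2` likewise gives a limit, < 8 mL/min/kg. Compound 3 `Cc1cc2c(cc1Cc1ccc(-c3cscn3)cc1)C(=O)N([C@H]1CCOC[C@@H]1O)C2` gives 10 mL/min/kg in this assay and is thus the only one of the three with a number rather than a limit, the other two sitting at the limit of < 8 mL/min/kg in this assay, at which 2 of the 3 values shown sit. The step from compound 1 to compound 3 is an at least 1.2-fold higher number from compound 1 to compound 3 (0.09 log units; that floor lies within the scatter), and that from compound 2 to compound 3 is an at least 1.2-fold higher number from compound 2 to compound 3 (0.09 log units; that floor lies within the scatter); the step that the two limits leave unreadable from compound 1 to compound 2 cannot be read, as both of its ends are limits.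

Compound 4 `Cc1nc(-c2ccc(Cc3cc4c(cc3C)CN([C@H]3CCOC[C@@H]3O)C4=O)cc2)co1` differs from compound 3 by 2-methyl-1,3-oxazol-4-yl in place of 1,3-thiazol-4-yl on an aromatic carbon. The measured step that bears on it is an at least 1.2-fold higher number from compound 1 to compound 3 (0.09 log units; that floor lies within the scatter), which goes from the oxazol-4-yl to the thiazol-4-yl; compound 4 returns to an oxazole, now the 2-methyl-1,3-oxazol-4-yl. The step from compound 3 to compound 4 is therefore expected to be a 1.4-fold lower number from compound 3 to compound 4 (0.15 log units; within the scatter), a small decrease likely ending at the limit. Compound 4 is estimated at 7 mL/min/kg, within a range of 4 mL/min/kg to 12 mL/min/kg.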

Compound 4, clearance: 13 mL/min/kg
Beside the measured number, compound 4's estimate is 1.9-fold (0.27 log units) below it, outside the stated range (above it).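

In this assay the 2-methyl-1,3-oxazol-4-yl and the 1,3-thiazol-4-yl on this aromatic carbon do not separate (a 1.3-fold higher number from compound 3 to compound 4 (0.11 log units; within the scatter)). Methyl in place of hydrogen on the oxazole gives a number where the unsubstituted oxazole gives only a limit (an at least 1.6-fold higher number from compound 1 to compound 4 (0.21 log units; that floor lies within the scatter)), and the comparison with the 1H-pyrazol-1-yl reads alike (an at least 1.6-fold higher number from compound 2 to compound 4 (0.21 log units; that floor lies within the scatter)), with both floors lying within the scatter. This position now holds two rings with numbers and two with limits: the limit of < 8 mL/min/kg in this assay, at which 2 of the 4 values shown sit.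

As far as these compounds go, the true size of the steps that start from a limit stays open, and the step between the two limits cannot be read. Also open, from the compounds shown here alone, is how an amine or a carboxylic acid at this place, or a longer chain than methyl on the oxazole, would read in this assay.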